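The source may hold more compounds than are shown below. What is called first, only, known or untested is meant among the compounds shown, and "the series" means these compounds.

Three ureas sharing the core of compound 1 `COC(=O)c1ccc(NC(=O)Nc2cc(C)nc3ccccc23)cc1` have been measured in a physicochemical assay for solubility, at pH 7.4; on this read-out higher numbers stand for higher solubility and lower numbers for lower solubility. In this assay compound 1 gives 1200 nM, the lowest of the three numbers. Compound 3 `Cc1cc(NC(=O)Nc2cccc(C(C)(C)C)c2)c2ccccc2n1` gives 34700 nM in this assay, and compound 2 `Cc1cc(NC(=O)Nc2ccccc2N)c2ccccc2n1` gives 51800 nM in this assay; both of these readings lie beyond the scatter above that of compound 1, the gap to compound 2 being the wider one. Within the data shown here, no single-point step between any two of the measured compounds has been worked out, so the account rests on the bare numbers.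

Compound 4 `Cc1cc(NC(=O)Nc2ccc(OC(F)(F)F)cc2)c2ccccc2n1` has not yet been measured in this assay. It differs from compound 1 in one place: trifluoromethoxy in place of methoxycarbonyl on an aromatic carbon. The methoxycarbonyl that leaves carries two hydrogen-bond acceptors, while the trifluoromethoxy that enters carries one, and the change sits para to a large group on the outer ring.

Compound 1 stands far below its two companions, and any move away from its substitution pattern is expected to carry the number upward rather than downward. The step from compound 1 to compound 4 is therefore estimated as an increase beyond the scatter, a 7.5-fold higher number from compound 1 to compound 4 (0.88 log units; beyond the scatter). Compound 4 is expected to give about 9000 nM in this assay, with a likely range from 2500 nM to 40000 nM.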

Compound 4, solubility: 300 nM
Estimate against measurement, compound 4: 30-fold (1.48 log units) above; the measured number lies below the stated range.
By their numbers in this assay, from the lowest: compound 4; then compound 1; then compounds 3 and 2 (each within the scatter of the next).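

In this assay, placing trifluoromethoxy where methoxycarbonyl stood on an aromatic carbon, para to a large group, gives a 4.0-fold lower number from compound 1 to compound 4 (0.60 log units; beyond the scatter). This first single-place step in the series shows that the number at this position can move down as well as up, so compound 1 does not mark a floor for the series. It also shows that the two groups are not interchangeable at this position, even though neither carries a ring, a hydrogen-bond donor or a net charge, and the step is beyond the scatter. Nothing measured here bears on why the number falls.

The compounds shown leave open how the number would respond if a carboxylic acid or a primary amide stood on the same aromatic carbon, with the rest of compound 1 unchanged. They also leave open whether a plain methoxy group there would fall closer to compound 1 or to compound 4, and a single step cannot say whether the acceptor count tracks the read-out at all.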